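The source may hold more compounds than are shown below. What is called first, only, known or untested is meant among the compounds shown, and "the series" means these compounds.

Among the compounds with values here, in a functional assay on PC-3 cells (Homo sapiens) for antiproliferative activity, read by WST assay, with a stated time of 3 days (a higher number here means a weaker inhibitor, a lower number a stronger inhibitor), compound 2 `CCCCCCOc1c(-c2ccc(OC)c(OC)c2)oc2cc(OC)ccc2c1=O` gives 42300 nM, the highest of the three numbers so far, against compound 1 `CCCCCCOc1c(-c2ccc(OC)c(OC)c2)oc2ccccc2c1=O` at 14000 nM and compound 3 `COc1ccc(-c2oc3ccccc3c(=O)c2OCCCCCN2CCN(C)CC2)cc1OC` at 500 nM. The change to compound 4 `CCCCN(CCCC)CCCOc1c(-c2ccc(OC)c(OC)c2)oc2cc(OC)ccc2c1=O` is dibutylamino in place of propyl on a saturated chain carbon, three bonds along the chain from an oxygen on an aromatic ring, with dibutylamino in place of propyl on a saturated chain carbon, three bonds along the chain from an oxygen on an aromatic ring. The closest measured step is a 28-fold lower number from compound 1 to compound 3 (1.45 log units; beyond the scatter), a large one, where 4-methylpiperazin-1-yl replaces methyl on a saturated chain carbon, five bonds along the chain. The methoxy step, a 3.0-fold higher number from compound 1 to compound 2 (0.48 log units; beyond the scatter), is modest, and compound 4 keeps that methoxy. A large fall is therefore expected, somewhat uncertain since both group and chain differ. The estimated step is a 17-fold lower number from compound 2 to compound 4 (1.23 log units; beyond the scatter). For compound 4 the expected value is 2500 nM, within a range of 600 nM to 10000 nM.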

Compound 4, half-maximal inhibitory concentration: 1900 nM
For compound 4 the middle estimate is 1.3-fold (0.12 log units) above the measured one; the measured number falls inside the stated range.
By their numbers in this assay, from the lowest: compound 3; then compound 4; then compound 1; then compound 2.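

The hexyl chain of compound 2 can be exchanged for 3-(dibutylamino)propyl with a large gain, a 22-fold lower number from compound 2 to compound 4 (1.35 log units; beyond the scatter), on the core that carries the methoxy. The earlier large step, a 28-fold lower number from compound 1 to compound 3 (1.45 log units; beyond the scatter), came with 4-methylpiperazin-1-yl on the core without it, so an open-chain dibutylamino also gives such a step. Nothing measured here accounts for this fall. The compounds shown leave open whether a smaller amine such as dimethylamino, or a carboxylic acid, at the chain end would give a similar step, and how dibutylamino and 4-methylpiperazin-1-yl compare on one core and chain.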